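The source may hold more compounds than are shown below. What is called first, only, known or untested is meant among the compounds shown, and "the series" means these compounds.

Compounds measured:
- compound 1, `Cc1cc2c(cc1C)C(Cl)=C(/C=N\NC(=O)C1=C(Cl)c3ccccc3CCC1)CCC2`: 4500 nM
- compound 2, `COc1cccc(C(=O)N/N=C/C2=C(Cl)c3ccccc3CCC2)c1C`: 9200 nM
- compound 3, `Cc1ccc(C(=O)N/N=C/C2=C(Cl)c3cc(C)c(C)cc3CCC2)cc1`: > 100000 nM

Three hydrazone amides of this series have been tested in a functional assay on HeLa cells (Homo sapiens) for inhibition, read by sulforhodamine B assay, with a stated time of 48 h; on this read-out lower numbers stand for stronger inhibition of growth and higher numbers for weaker inhibition of growth. In this assay compound 1 gives 4500 nM and compound 2 gives 9200 nM. For compound 3 this assay reports only a limit, > 100000 nM, so compound 3 has no number of its own and stands at the limit of > 100000 nM in this assay, at which 1 of the 3 values shown sits.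

The next compound, compound 4 with structure `Cc1cc2c(cc1C)C(Cl)=C(/C=N/NC(=O)c1cccc(I)c1)CCC2`, keeps the core of compound 3 and differs in one place: 3-iodophenyl in place of 4-methylphenyl on a carbonyl carbon. Among the measured compounds shown here, no step between two measured compounds mirrors this exchange, so the size of its effect has no precedent here. Since compound 3 sits only at a limit, any change from it toward a measurable number would be a gain, and compounds 1 and 2 show that amides of this core can reach the low micromolar region. Compound 4 is therefore expected to give 40000 nM, with a range from 8000 nM to 200000 nM. That estimate implies an expected step of an at least 2.5-fold lower number from compound 3 to compound 4 (0.39 log units; beyond the scatter), its direction uncertain because compound 3 is known only as a limit.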

Compound 4, concentration for 50% growth inhibition: > 100000 nM
Compound 4: no number, only a limit; the forecaster's own chance of this, stated with the estimate: 40%; middle value at least 2.5-fold (0.39 log units) away from the limit.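

In this assay, compound 3 and compound 4 both stand only at a limit, so no step can be read between them: the limit of > 100000 nM in this assay, at which 2 of the 4 values shown sit.

The compounds shown leave open whether 3-iodophenyl in place of 4-methylphenyl on a carbonyl carbon changes growth inhibition at all, and by how much.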